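Aryl swap on the shared core: compound 2 to compound 3

The source may hold more compounds than are shown below. What is called first, only, known or untested is meant among the compounds shown, and "the series" means these compounds.

Measured in a functional assay on A549 cells (Homo sapiens) for antiproliferative activity, read by MTT assay, with a stated time of 72 h; a higher number here means a weaker inhibitor, a lower number a stronger inhibitor:
- compound 1 `COc1cc(-n2cnc3ccc(-c4ccc(C(C)=O)cc4)cc32)cc(OC)c1OC`: 2510 nM
- compound 2 `COc1cc(-n2cnc3ccc(-c4cccc(C)c4C)cc32)cc(OC)c1OC`: 9250 nM

Compound 2 has the higher of the two numbers, at 9250 nM. Compound 3 `COc1ccc(-c2ccc3ncn(-c4cc(OC)c(OC)c(OC)c4)c3c2)cc1` carries 4-methoxyphenyl in place of 2,3-dimethylphenyl on an aromatic carbon. Going by the values given here, one measured step bears on this change: a 3.7-fold higher number from compound 1 to compound 2 (0.57 log units; beyond the scatter). Among the compounds with values here, it is modest, and it is the only evidence available. Since 4-methoxyphenyl, like the 4-acetylphenyl of compound 1, is named as a 4-substituted phenyl, a partial return towards compound 1 is expected. The expected step is a 2.1-fold lower number from compound 2 to compound 3 (0.31 log units; beyond the scatter). For compound 3 the estimated value is 4500 nM, with an expected range of 1800 nM to 11000 nM.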

Compound 3, half-maximal inhibitory concentration: > 10000 nM
Compound 3 ended at the assay's limit (the forecaster's own chance of this, stated with the estimate: 5%); middle value at least 2.2-fold (0.34 log units) from the limit.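

In this assay compound 3 gives > 10000 nM, a limit of the assay and not a number. Changing acetyl to methoxy on the 4-substituted phenyl gives an at least 3.9-fold higher number from compound 1 to compound 3 (0.60 log units; beyond the scatter), so a 4-substituted phenyl alone does not hold the level of compound 1. Changing 2,3-dimethylphenyl to 4-methoxyphenyl gives an at least 1.0-fold higher number from compound 2 to compound 3 (0.03 log units; that floor lies within the scatter), which fixes no order between these two aryl groups.

Still open, from the compounds shown here alone, is whether an amine or a carboxylic acid at the 4-position of this phenyl would match compound 1 or improve on it.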